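Thiophene to furanyl ketone at the same ring position

The source may hold more compounds than are shown below. What is called first, only, known or untested is meant among the compounds shown, and "the series" means these compounds.

Compound 1 `CCOC(=O)c1cnc(C(F)(F)F)nc1NN1C(=O)C=C(C)C1=O`: 1000 nM
Compound 2 `CCOC(=O)c1cnc(-c2cc(Cl)nc(Cl)c2)nc1NN1C(=O)C=C(C)C1=O`: 2000 nM
Compound 3 `CCOC(=O)c1cnc(-c2ccc(C)s2)nc1NN1C(=O)C=C(C)C1=O`: 200 nM

The three measured compounds share one core and differ only in a single group on an aromatic carbon. In a functional assay on Jurkat cells for inhibition of nuclear factor NF-kappa-B complex (Homo sapiens) (on this read-out higher numbers stand for weaker inhibition and lower numbers for stronger inhibition), compound 3 gives the lowest number of the three: the step of a 5.0-fold lower number from compound 1 to compound 3 (0.70 log units; beyond the scatter) and the step of a 10-fold lower number from compound 2 to compound 3 (1.00 log units; beyond the scatter) both lie beyond the scatter, so compound 3 is the strongest inhibitor measured so far.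

Compound 4 `CCOC(=O)c1cnc(C(=O)c2ccco2)nc1NN1C(=O)C=C(C)C1=O` has not yet been measured. It differs from compound 3 in one place: (furan-2-yl)carbonyl in place of 5-methylthiophen-2-yl on an aromatic carbon. The two steps that bear on this position both ended at compound 3 and were of modest size, showing that the group here can move the number by more than the scatter in either direction. Going by the values given here, no measured step involves a carbonyl-linked ring, so the direction is uncertain; the directly attached thiophene in compound 3 set the best value, and a departure from it is expected to cost somewhat.

Compound 4 is therefore expected to give 600 nM in this assay, with a range from 150 nM to 2500 nM. This estimate means an expected step of a 3.0-fold higher number from compound 3 to compound 4 (0.48 log units; beyond the scatter).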

Compound 4, half-maximal inhibitory concentration: 700 nM
Beside the measured number, compound 4's estimate is 1.2-fold (0.07 log units) below it, within the range that was stated.
By their numbers in this assay, from the lowest: compound 3; then compounds 4, 1 and 2 (each within the scatter of the next, the first and the last beyond it).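

In this assay, replacing the directly attached 5-methylthiophen-2-yl with a ring held through a carbonyl gives a 3.5-fold higher number from compound 3 to compound 4 (0.54 log units; beyond the scatter), so compound 3 remains the strongest inhibitor of the series. The new group still gives a 2.9-fold lower number from compound 2 to compound 4 (0.46 log units; beyond the scatter), while a 1.4-fold lower number from compound 1 to compound 4 (0.15 log units; within the scatter) leaves those two compounds indistinguishable, so a carbonyl-linked furan reads no differently here from a plain trifluoromethyl. No measurement on hand explains these differences.

This change alters the ring and adds the carbonyl at once, and the compounds shown include neither a directly attached furan-2-yl nor a thiophene joined through a carbonyl, so the two contributions remain unseparated. Also open, going by these compounds, is how an amine or a carboxylic acid at this position would read.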